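Weak cytotoxicity against a gastric cell line: fluoro to trifluoromethyl

This account rests on a few compounds, and the source may have more. Where it says the series, first, only, none or still open, it means among the compounds named here.

Measured so far:
compound 1 `Cc1cc(Nc2cc(-c3ccccc3)[nH]n2)n2nc(SCCCc3ccccc3)nc2n1` — 40200 nM
compound 2 `Cc1cc(Nc2cc(-c3ccccc3)[nH]n2)n2nc(SCc3ccc(F)cc3)nc2n1` — 35500 nM

Both compounds were tested in an ADME assay on GES1 cells (Homo sapiens) for inhibition, read by MTT assay, with a stated time of 72 h; a higher number here means a weaker inhibitor, a lower number a stronger inhibitor. Compound 2 has the lowest of the two numbers, and its nearest neighbour is compound 1, where the step of a 1.1-fold lower number from compound 1 to compound 2 (0.05 log units; within the scatter) lies within the scatter; so the two compounds cannot be told apart on these numbers.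

Compound 3 `Cc1cc(Nc2cc(-c3ccccc3)[nH]n2)n2nc(SCc3ccc(C(F)(F)F)cc3)nc2n1` is not yet measured. It differs from compound 2 in one place: trifluoromethyl in place of fluoro on an aromatic carbon. Going by the values given here, the only measured step, a 1.1-fold lower number from compound 1 to compound 2 (0.05 log units; within the scatter), changed the whole group on the saturated chain carbon bound to a sulfur and still moved the number by almost nothing; a swap of one substituent on an aromatic carbon, from fluoro to trifluoromethyl, is a smaller change than that. Among the compounds with values here, there is no measured step that touches this position, so nothing beyond the scatter is expected in either direction.

Compound 3 is therefore estimated at 36000 nM, in a range of 15000 nM to 90000 nM, which means an expected step of a 1.0-fold higher number from compound 2 to compound 3 (0.01 log units; within the scatter).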

Compound 3, half-maximal inhibitory concentration: 42700 nM
The estimate for compound 3 lay 1.2-fold (0.07 log units) below the measured number; the range from low to high includes it.
By their numbers in this assay, from the lowest: compounds 2, 1 and 3 (each within the scatter of the next).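

Trifluoromethyl brings in 4 heavy atoms where fluoro had 1, yet in this assay that swap on the aromatic carbon gives a 1.2-fold higher number from compound 2 to compound 3 (0.08 log units; within the scatter), the first reading at this position, and it shows no change that can be told from the scatter. Replacing the phenethyl group with 4-(trifluoromethyl)phenyl on the saturated chain carbon bound to a sulfur gives a 1.1-fold higher number from compound 1 to compound 3 (0.03 log units; within the scatter), so this larger change at the chain also stays within the scatter, and all three compounds remain indistinguishable in this cell assay. No supporting measurement is available to explain this flat picture.

The compounds shown leave open whether an amine or a carboxylic acid on that aromatic carbon, or a plain alkyl chain on the sulfur with no aromatic ring at its end, would shift the number beyond the scatter. They also leave open what a change to the shared core would do, as that core is the same in all three compounds.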